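A few compounds are considered here, and "the series" means these few. Any claim that something is new, unique, unknown or untested is made for them only; others in the source may bear on it.

Compound 1 `Nc1cccc(Nc2c(C(=O)NCc3ccc(F)cc3)nc(Br)c3cccnc23)c1` and compound 2 `N[C@H]1CC[C@H](Nc2c(C(=O)NCc3cccc(C(F)(F)F)c3)nc(Br)c3cccnc23)CC1` share one core, and both were tested in a functional assay on MCF7 cells (Homo sapiens) for cytotoxicity, read by MTT assay, with a stated time of 72 h; a higher number here means a weaker inhibitor, a lower number a stronger inhibitor. There compound 1 gives 8000 nM, while compound 2 gives 15000 nM; these two numbers lie within the usual scatter of each other, and neither stands apart. Compound 3 `COC(=O)CNc1c(C(=O)NCc2ccc(F)cc2)nc(Br)c2cccnc12` has not yet been measured in this assay. It differs from compound 1 in one place: (methoxycarbonyl)methyl in place of 3-aminophenyl on a nitrogen on an aromatic ring. Among the measured compounds shown here, no measured pair shows what such an exchange does here. The step of a 1.5-fold higher number from compound 1 to compound 3 (0.18 log units; within the scatter) is expected to be small, towards a weaker inhibitor, and may well stay within the scatter. Compound 3 is estimated at 12000 nM, within a range from 4000 nM to 40000 nM.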

Compound 3, half-maximal inhibitory concentration: > 10000 nM
Compound 3: only a limit was reported (the forecaster's own chance of this, stated with the estimate: 15%); the middle value lies beyond the limit too.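

In this assay compound 3 gives only a limit, > 10000 nM, not a number. Putting (methoxycarbonyl)methyl in place of 3-aminophenyl on this nitrogen gives an at least 1.2-fold higher number from compound 1 to compound 3 (0.09 log units; that floor lies within the scatter), so losing the aromatic ring at this position brings no gain in strength. How large the real step is cannot be read, and it may be small or much larger: the limit of > 10000 nM in this assay, at which 1 of the 3 values shown sits.

As far as these compounds go, whether a carboxylic acid or an amine at the end of this chain would give a lower number stays open, as does the effect of a longer chain.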